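A methoxy group added to the pendant phenyl of compound 1

This account rests on a few compounds, and the source may have more. Where it says the series, first, only, none or still open, it means among the compounds named here.

Compound 1 `Cn1cc(-c2ccccc2)c2cc(C(=O)NCc3ccc(C(=O)Nc4ccccc4N)cc3)[nH]c2c1=O` gives 230 nM in a functional assay on MV4-11 cells (Homo sapiens) for antiproliferative activity, read by CCK-8 assay, with a stated time of 72 h (a higher number here means a weaker inhibitor, a lower number a stronger inhibitor), the second highest of three numbers: compound 2 `Cn1cc(-c2ccccc2Oc2ccccc2)c2cc(C(=O)NCCCCC(=O)Nc3ccccc3N)[nH]c2c1=O` gives 240 nM, within the scatter of compound 1, while compound 3 `Cn1cc(-c2ccccc2Oc2ccccc2)c2cc(C(=O)NCCCCCC(=O)Nc3ccccc3N)[nH]c2c1=O` gives 70 nM; the gap between compound 1 and compound 3 is a lower number for compound 3 that lies beyond the scatter. Within the data shown here, the only measured step, a 3.4-fold lower number from compound 2 to compound 3 (0.54 log units; beyond the scatter), concerns the chain rather than the aryl group. Compound 4 `COc1ccccc1-c1cn(C)c(=O)c2[nH]c(C(=O)NCc3ccc(C(=O)Nc4ccccc4N)cc3)cc12` differs from compound 1 by methoxy in place of hydrogen on an aromatic carbon. Among the measured compounds shown here, no measured step bears directly on this change; compounds 2 and 3 carry a larger group at this place but also a different chain, so their values show only that a substituent there is tolerated. A step within or barely beyond the scatter is therefore expected, a 1.3-fold lower number from compound 1 to compound 4 (0.11 log units; within the scatter). Compound 4 is estimated at 180 nM, between 70 nM and 450 nM.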

Compound 4, half-maximal inhibitory concentration: 200 nM
Compound 4: the middle estimate sits 1.1-fold (0.05 log units) below what was measured, within the range that was stated.
By their numbers in this assay, from the lowest: compound 3; then compounds 4, 1 and 2 (each within the scatter of the next).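

With the rest of compound 1 unchanged, the phenyl to 2-methoxyphenyl change gives a 1.2-fold lower number from compound 1 to compound 4 (0.06 log units; within the scatter) in this assay. Among these compounds, this is the first direct reading at this aromatic carbon, ortho to a large group, and it shows that methoxy can replace hydrogen there without a shift beyond the scatter. No available evidence bears on why this is so.

The compounds shown leave open whether an amine or a carboxylic acid on this carbon would read the same way. They also leave open how methoxy would read with the saturated chain of compound 3.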